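Notes on the step from compound 2 to compound 4

This account rests on a few compounds, and the source may have more. Where it says the series, first, only, none or still open, it means among the compounds named here.

Three compounds have numbers in an assay on isolated protein for inhibition of Alpha glucosidase (Homo sapiens), with stated times of 5 min and 15 min, tested at 50 uM; a lower number here means less inhibition, a higher number more inhibition at the concentration tested (going by the name of the read-out). Compound 1 `O=C(/C=C(O)/C=C/c1ccc(O)c(O)c1)c1ccccc1O` gives 93.6% in this assay. Compound 2 `O=C1/C(=C/c2ccccc2)CCC/C1=C\c1cccc(Br)c1` gives 27.2%, the second highest of the three; its nearest neighbour, compound 3 `COc1cc(/C=C2\CCC/C(=C\c3ccccc3)C2=O)cc(OC)c1OC`, gives 16.3%, a gap beyond the scatter, while compound 1 lies furthest away, far higher. Compound 4 `O=C1/C(=C/c2ccccc2)CCC/C1=C\c1cccc(O)c1` has not been measured in this assay. It differs from compound 2 in one place: hydroxy in place of bromo on an aromatic carbon. Among the compounds with values here, no step between two measured compounds carries this change, so the direction rests on the wider picture: a gain is expected because compound 1, carrying hydroxy groups, gives 93.6%. The expected step is a number 12.8 percentage points higher from compound 2 to compound 4 (beyond the scatter), beyond the scatter but modest. Compound 4 is expected at 40%, within 20% to 65%.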

Compound 4, a percentage reported as inhibition, at one concentration (the size of the read-out at that concentration, not a potency): 65.1%
Compound 4: middle estimate off by 25.1 percentage points, on the low side, and the stated range ends below it.
By their numbers in this assay, from the lowest: compound 3; then compound 2; then compound 4; then compound 1.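

Going from 3-bromophenyl to 3-hydroxyphenyl gives a number 37.9 percentage points higher from compound 2 to compound 4 (beyond the scatter) in this assay and is the first direct reading of this change in the series. This place on the aromatic ring is therefore not indifferent to its substituent: exchanging one heavy atom for another moves inhibition well beyond the scatter. No available evidence bears on the reason for this gain. The compounds shown leave open whether an amine or a carboxylic acid at the same place would keep the gain, and whether a second hydroxy on the other aromatic ring would add to it.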